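Regiochemistry of the Fluoropyridyl Group: Compound 2 to Compound 3

The compounds below may be only part of what the source reports. "The series", "measured", "known", "first", "only" and "open" are said of these compounds alone.

Compound 2 `O=C1CC(N2CCN(c3ncccn3)CC2)CN1c1cccc(-c2ccc(F)nc2)c1` carries a fluoropyridyl group on the shared core. In an assay on isolated protein for inhibition of Monoglyceride lipase (Mus musculus), with a stated time of 30 min (a higher number here means a weaker inhibitor, a lower number a stronger inhibitor), compound 2 gives 2100 nM, the highest of the two numbers recorded so far. Within the data shown here, its nearest neighbour is compound 1 `COc1ccccc1-c1cccc(N2CC(N3CCN(c4ncccn4)CC3)CC2=O)c1`, which in this assay gives 85 nM; the only measured step, a 25-fold higher number from compound 1 to compound 2 (1.39 log units; beyond the scatter), is large and beyond the scatter, and it follows from exchanging the 2-methoxyphenyl for the 6-fluoropyridin-3-yl.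

Compound 3 `O=C1CC(N2CCN(c3ncccn3)CC2)CN1c1cccc(-c2cccnc2F)c1` keeps every atom of compound 2 and differs only in how they are joined: 2-fluoropyridin-3-yl in place of 6-fluoropyridin-3-yl on an aromatic carbon. Among the measured compounds shown here, no measured pair speaks directly to this exchange of one fluoropyridyl isomer for another; the step from compound 1 to compound 2 only shows that the aromatic group at this position matters strongly. With both isomers sharing the same atoms, the expectation is a modest step, a 2.1-fold lower number from compound 2 to compound 3 (0.32 log units; beyond the scatter), with wide uncertainty in either direction. For compound 3 in this assay the estimate is therefore 1000 nM, within a range of 200 nM to 5000 nM.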

Compound 3, half-maximal inhibitory concentration: 305 nM
Beside the measured number, compound 3's estimate is 3.3-fold (0.52 log units) above it, and the stated range covers the measured number.
By their numbers in this assay, from the lowest: compound 1; then compound 3; then compound 2.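

In this assay the two fluoropyridyl isomers are far from equivalent at this position: with the same atoms and the same counts of heavy atoms and hydrogen-bond acceptors, the exchange of 6-fluoropyridin-3-yl for 2-fluoropyridin-3-yl gives a 6.9-fold lower number from compound 2 to compound 3 (0.84 log units; beyond the scatter), so how the atoms are joined within the group matters here, and not only which atoms it contains. The 2-fluoropyridin-3-yl group closes much of the gap opened by the first exchange but not all of it, with a 3.6-fold higher number from compound 1 to compound 3 (0.55 log units; beyond the scatter), which leaves the 2-methoxyphenyl group of compound 1 with the lowest number of the three. No supporting measurement is available to explain why the two isomers differ.

The compounds shown leave open whether the fluorine or the ring nitrogen carries the difference between the isomers, a question that a plain pyridin-3-yl group or a 2-fluorophenyl group at this place would address. Also open, from the compounds shown here alone, is whether a 2-methoxypyridin-3-yl group, which would combine the methoxy group of compound 1 with the ring nitrogen of compound 3, would match the 2-methoxyphenyl group.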